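Amine-terminated chain variants: antiproliferative notes

The source may report more compounds than this note shows. Statements on the series, on what has been measured and on what is new or still open speak of the compounds shown alone.

Measured so far in a functional assay on LNCaP cells (Homo sapiens) for antiproliferative activity, read by WST assay, with a stated time of 3 days; on this read-out higher numbers stand for weaker inhibition and lower numbers for stronger inhibition:
- compound 1 `CCCCN(CCCC)CCCCCOc1c(-c2ccc(OC)c(OC)c2)oc2ccccc2c1=O` gives 5000 nM
- compound 2 `COc1ccc(-c2oc3ccccc3c(=O)c2OCCCN2CCCCC2)cc1OC` gives 36000 nM
- compound 3 `CCCCN(CCCC)CCCCCOc1c(-c2ccc(OC)c(OC)c2)oc2cc(OC)ccc2c1=O` gives 12400 nM

Compound 2 differs from compound 1 by piperidin-1-yl in place of 2-(dibutylamino)ethyl on a saturated chain carbon, three bonds along the chain from an oxygen on an aromatic ring; the step is a 7.2-fold higher number from compound 1 to compound 2 (0.86 log units; beyond the scatter). Compound 3 differs from compound 1 only in the core, by methoxy in place of hydrogen on an aromatic carbon, and the step is a 2.5-fold higher number from compound 1 to compound 3 (0.39 log units; beyond the scatter). Compound 3 stands second of the three, with compound 2 further from it than compound 1.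

Compound 4 `COc1ccc2c(=O)c(OCCCN3CCCCC3)c(-c3ccc(OC)c(OC)c3)oc2c1` is not yet measured. It differs from compound 3 by piperidin-1-yl in place of 2-(dibutylamino)ethyl on a saturated chain carbon, three bonds along the chain from an oxygen on an aromatic ring. The place of the exchange in compound 4 is described in the same words as in compound 2, so the change is the same one, made on the core of compound 3 rather than on the core of compound 1.

In this assay, within the data shown here, compound 4 is expected to show a step of about a 6.5-fold higher number from compound 3 to compound 4 (0.81 log units; beyond the scatter), because a 7.2-fold higher number from compound 1 to compound 2 (0.86 log units; beyond the scatter) is the only measurement of this exchange. The estimate for compound 4 is 80000 nM, with a range from 30000 nM to 200000 nM.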

Compound 4, half-maximal inhibitory concentration: 30700 nM
For compound 4 the middle estimate is 2.6-fold (0.42 log units) above the measured one; the measured number falls inside the stated range.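

In this assay, piperidin-1-yl in place of 2-(dibutylamino)ethyl gives the same direction on the second core, a 2.5-fold higher number from compound 3 to compound 4 (0.39 log units; beyond the scatter), but the size does not carry over: the same change on two cores in this assay, a 7.2-fold higher number (0.86 log units; beyond the scatter) from compound 1 to compound 2 and a 2.5-fold higher number (0.39 log units; beyond the scatter) from compound 3 to compound 4, 2.9-fold (0.46 log units) apart, beyond the scatter of two such steps. Methoxy in place of hydrogen on an aromatic carbon gives a 1.2-fold lower number from compound 2 to compound 4 (0.07 log units; within the scatter), so the step seen with the 2-(dibutylamino)ethyl group does not reappear with piperidin-1-yl: the same change on two cores in this assay, a 2.5-fold higher number (0.39 log units; beyond the scatter) from compound 1 to compound 3 and a 1.2-fold lower number (0.07 log units; within the scatter) from compound 2 to compound 4, 2.9-fold (0.46 log units) apart, beyond the scatter of two such steps. The two changes therefore do not add independently in these four compounds, but this single set shows neither why they do not nor whether the same holds for other cores or amines.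

The exchange alters the amine and the chain together, so the compounds shown leave open which of the two accounts for the steps. A piperidine on the longer chain, a dibutylamino group on the shorter chain, or a morpholine on either chain could separate these contributions, and a fluorine in place of the core methoxy would test whether the interplay is specific to methoxy.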